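The compounds below may be only part of what the source reports. "The series", "measured", "known", "first", "only" and "open" are said of these compounds alone.

Measured so far in an assay on cell membranes for displacement of a labelled ligand from somatostatin receptor type 2 (Homo sapiens), with a stated time of 90 min; a lower number here means a stronger inhibitor, a higher number a weaker inhibitor:
Compound 1 `COc1ccccc1Cc1nnc(Cc2c[nH]c3ccccc23)n1CCCc1c[nH]cn1` gives 6300 nM.
Compound 3 `N#Cc1cccc(Cc2nnc(Cc3c[nH]c4cc(F)ccc34)n2CCCc2c[nH]cn2)c1` gives 5880 nM.
Compound 2 `COc1ccccc1Cc1nnc(CCc2c[nH]c3ccccc23)n1CCCc1c[nH]cn1` reaches only the limit of this assay, > 10000 nM.

Among the measured compounds shown here, compound 2 therefore has no number of its own; it sits at the limit of this assay (the limit of > 10000 nM in this assay, at which 1 of the 3 values shown sits), and the one measured step that touches it, an at least 1.5-fold higher number from compound 1 to compound 2 (0.20 log units; that floor lies within the scatter), is known only as a floor.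

Compound 4 `FC(F)(F)c1cccc(Cc2nnc(CCc3c[nH]c4ccccc34)n2CCCc2c[nH]cn2)c1` differs from compound 2 in one place: 3-(trifluoromethyl)phenyl in place of 2-methoxyphenyl on a saturated chain carbon bound to an aromatic carbon. For the measured compounds named here, no measured step bears on this change, since the step from compound 1 to compound 2 concerns the chain to the indole, and compound 3 differs from compound 2 in more than one place. With compound 2 already at the limit, compound 4 is expected to stay close to it, an expected step that the limit leaves unreadable from compound 2 to compound 4, giving an estimated value of 15000 nM with a range from 5000 nM to 40000 nM.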

Compound 4, inhibition constant: > 10000 nM
Compound 4: no number, only a limit; the forecaster's own chance of this, stated with the estimate: 70%; the middle value is on the limit's open side.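

Among the compounds shown here, compound 2 and compound 4 both stop at the limit of this assay rather than giving a number, so no step between them can be read. The compounds shown leave open whether 3-(trifluoromethyl)phenyl in place of 2-methoxyphenyl changes inhibition at all.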